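A few compounds are considered here, and "the series" means these few. Any claim that something is new, unique, unknown or untested is made for them only; others in the source may bear on it.

The shared core of compound 1 `CN1C[C@H](C(=O)Nc2ccccc2)[C@@H](c2ccc(/C=C/C(=O)Nc3ccccc3N)cc2)C1` carries a plain phenyl on its amide. Going by the values given here, in an in vitro ADME assay on microsomes from liver (Homo sapiens) for pharmacokinetics, read by LC-MS, with a stated time of 10 min, tested at 1 uM (a higher number here means faster removal of the compound, a lower number slower removal), compound 1 gives 7 mL/min/kg, the second highest of the three numbers known. Compound 2 `CC(C)c1ccc(NC(=O)[C@H]2CN(C)C[C@@H]2c2ccc(/C=C/C(=O)Nc3ccccc3N)cc2)cc1` gives 10 mL/min/kg in this assay, and compound 3 `CN1C[C@H](C(=O)Nc2ccc(Br)cc2)[C@@H](c2ccc(/C=C/C(=O)Nc3ccccc3N)cc2)C1` gives 3 mL/min/kg. The step from compound 1 to compound 2 is a 1.4-fold higher number from compound 1 to compound 2 (0.15 log units; within the scatter), while a 2.3-fold lower number from compound 1 to compound 3 (0.37 log units; beyond the scatter) and a 3.3-fold lower number from compound 2 to compound 3 (0.52 log units; beyond the scatter) are the two steps that reach beyond the scatter.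

Compound 4 `Cc1cccc(NC(=O)[C@H]2CN(C)C[C@@H]2c2ccc(/C=C/C(=O)Nc3ccccc3N)cc2)c1` differs from compound 1 by one change: methyl in place of hydrogen on an aromatic carbon. The step that bears most on this is the one in which isopropyl replaced hydrogen on the same ring, which gave a 1.4-fold higher number from compound 1 to compound 2 (0.15 log units; within the scatter); only the bromo step moved the number beyond the scatter, with a 2.3-fold lower number from compound 1 to compound 3 (0.37 log units; beyond the scatter). A single added methyl is therefore expected to give a step of about no change at the digits printed from compound 1 to compound 4 (within the scatter), within the scatter and in no clear direction. Compound 4 is estimated at 7 mL/min/kg, with a range from 4 mL/min/kg to 14 mL/min/kg.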

Compound 4, clearance: 14 mL/min/kg
Beside the measured number, compound 4's estimate is 2.0-fold (0.30 log units) below it; measured number inside the range.
By their numbers in this assay, from the lowest: compound 3; then compounds 1, 2 and 4 (each within the scatter of the next).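

In this assay, adding one methyl to the plain phenyl ring gives a 2.0-fold higher number from compound 1 to compound 4 (0.30 log units; within the scatter), so this small group at this place leaves the number within the scatter. Exchanging 4-isopropylphenyl for 3-methylphenyl gives a 1.4-fold higher number from compound 2 to compound 4 (0.15 log units; within the scatter), so this assay does not tell these two substituted rings apart, even though their groups differ in both size and place. Going by these compounds alone, exchanging 4-bromophenyl for 3-methylphenyl gives a 4.7-fold higher number from compound 3 to compound 4 (0.67 log units; beyond the scatter), which leaves compound 3 as the only one whose steps to all the others reach beyond the scatter.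

No measurement shown gives a cause for these numbers. Still open, as far as these compounds go, is whether the group or its place on the ring matters more, which 3-bromophenyl and 4-methylphenyl would help to separate, and how a ring carrying an amine or a carboxylic acid would behave.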